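The source may hold more compounds than are shown below. What is called first, only, known or untested is meant among the compounds shown, and "the series" means these compounds.

Measured so far:
compound 1, `COc1ccc(NS(=O)(=O)/C=C/c2c(F)c(F)c(F)c(F)c2F)cc1[N+](=O)[O-]`, 100000 nM;
compound 2, `COc1ccc(NS(=O)(=O)/C=C/c2c(F)c(F)c(F)c(F)c2F)cc1N`, 75000 nM;
compound 3, `COc1ccc(/C=C/S(=O)(=O)Nc2c(F)c(F)c(F)c(F)c2F)cc1[N+](=O)[O-]`, 100000 nM.

These three were tested in a functional assay on DU-145 cells (Homo sapiens) for cytotoxicity, read by trypan blue exclusion, with a stated time of 96 h; a lower number here means a stronger inhibitor, a higher number a weaker inhibitor. The change from compound 1 to compound 2 is amino in place of nitro on an aromatic carbon; it made a 1.3-fold lower number from compound 1 to compound 2 (0.12 log units; within the scatter). Compound 3 has the same atoms as compound 1 joined differently, and the difference between the two cores is not broken down here; compound 3 gives 100000 nM, level with compound 1 at the digits reported.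

Compound 4, `COc1ccc(/C=C/S(=O)(=O)Nc2c(F)c(F)c(F)c(F)c2F)cc1N`, is not yet measured. It arises from compound 3 by amino in place of nitro on an aromatic carbon, the same change made from compound 1 to compound 2. Resting on that earlier step, a 1.3-fold lower number from compound 1 to compound 2 (0.12 log units; within the scatter), the step from compound 3 to compound 4 is expected to be a 1.3-fold lower number from compound 3 to compound 4 (0.12 log units; within the scatter). Compound 4 is therefore estimated at 75000 nM, between 30000 nM and 150000 nM.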

Compound 4, half-maximal inhibitory concentration: 35000 nM
Compound 4: the middle estimate sits 2.1-fold (0.33 log units) above what was measured; the range from low to high includes it.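

In this assay, amino in place of nitro on an aromatic carbon gave a 2.9-fold lower number from compound 3 to compound 4 (0.46 log units; beyond the scatter) on the rearranged core, and the step does not differ measurably from the one on the core of compound 1: the same change on two cores in this assay, a 1.3-fold lower number (0.12 log units; within the scatter) from compound 1 to compound 2 and a 2.9-fold lower number (0.46 log units; beyond the scatter) from compound 3 to compound 4, 2.1-fold (0.33 log units) apart, within the scatter of two such steps. The change therefore carries across these two cores without a detectable difference in its size. This rests on a single pair of steps, one of them within the scatter, and it shows neither that the step has a fixed size nor that it would hold on any other core.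

The compounds shown leave open how an acetamide, a hydroxyl or a dimethylamino group would read in place of the amino group. They also leave open whether the step persists when the methoxy group is replaced by a hydrogen or an ethoxy group.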